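A few compounds are considered here, and "the series" means these few. Any claim that something is new, unique, unknown or untested is made for them only; others in the source may bear on it.

Measured so far in a functional assay on PC-3 cells (Homo sapiens) for inhibition, read by sulforhodamine B assay; on this read-out higher numbers stand for weaker inhibition of growth and lower numbers for stronger inhibition of growth:
- compound 1 `COc1ccc(-c2ccc(-c3ccc(-c4nc5cc(C)ccc5[nH]4)cc3)cc2)cc1OC`: 2560 nM
- compound 2 `CN(C)c1ccc(-c2ccc(-c3ccc(-c4nc5ccccc5[nH]4)cc3)cc2)cc1`: 100000 nM
- compound 3 `Clc1cccc(-c2ccc(-c3ccc(-c4nc5ccccc5[nH]4)cc3)cc2)c1`: 33700 nM

Compound 3, at 33700 nM, holds the middle of these three numbers, with compound 2 higher and compound 1 lower. Within the data shown here, the next molecule, compound 4 `COc1ccc(-c2ccc(-c3ccc(-c4nc5ccccc5[nH]4)cc3)cc2)cc1OC`, has no measurement yet. It keeps the core of compound 3 and differs in one place: 3,4-dimethoxyphenyl in place of 3-chlorophenyl on an aromatic carbon.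

Among the measured compounds shown here, the one measured step at this same place is a 3.0-fold lower number from compound 2 to compound 3 (0.47 log units; beyond the scatter). That step is modest but beyond the scatter, so exchanging this outer group can move the number. Compound 1 also carries the 3,4-dimethoxyphenyl group, on a core that is not quite the same, and compound 1 gives 2560 nM. Its number sits well under that of compound 3, so a move towards stronger inhibition of growth is expected in this assay, of a size beyond the scatter. The expected change is a 5.6-fold lower number from compound 3 to compound 4 (0.75 log units; beyond the scatter). Compound 4 is estimated at 6000 nM, with an expected range of 2000 nM to 25000 nM.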

Compound 4, concentration for 50% growth inhibition: 47100 nM
The estimate for compound 4 lay 7.9-fold (0.89 log units) below the measured number; the whole stated range lies below it.
By their numbers in this assay, from the lowest: compound 1; then compounds 3 and 4 (each within the scatter of the next); then compound 2.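

In this assay, the step of a 1.4-fold higher number from compound 3 to compound 4 (0.15 log units; within the scatter) leaves 3-chlorophenyl and 3,4-dimethoxyphenyl indistinguishable at this position, while a 2.1-fold lower number from compound 2 to compound 4 (0.33 log units; beyond the scatter) separates 3,4-dimethoxyphenyl only modestly from 4-(dimethylamino)phenyl. The much larger change is an 18-fold higher number from compound 1 to compound 4 (1.26 log units; beyond the scatter) on removing one methyl from the core, so the low number of compound 1 goes with that methyl and not with the 3,4-dimethoxyphenyl group it shares with compound 4. Nothing else measured on these compounds explains either result.

As far as these compounds go, it remains open whether the methyl on the core would have a similar effect with 3-chlorophenyl or 4-(dimethylamino)phenyl as the outer group. It is also unknown how a carboxylic acid or a longer chain on the outer ring would read in this assay on this core.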